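The compounds below may be only part of what the source reports. "The series", "measured", "known", "first", "only" and "open" are said of these compounds alone.

Measured compounds:
compound 1, `CC(C)[C@@H]1CC[C@@H](C)C[C@@]12N(C)C(=O)[C@@H]1[C@H]3C(=O)N(C)C(=O)[C@H]3ON12`: in a functional assay, read by spectrophotometry, with a stated time of 2 h, tested at 3 mg/mL (on this read-out higher numbers stand for a stronger effect at the one concentration tested and lower numbers for a weaker effect), compound 1 gives 75.3%
compound 2, `CC(C)[C@@H]1CC[C@@H](C)C[C@@]12N(C)C(=O)[C@@H]1[C@H]3C(=O)N(c4ccccc4)C(=O)[C@H]3ON12`: in this assay compound 2 gives 73.5%
compound 3, `CC(C)[C@@H]1CC[C@@H](C)C[C@@]12N(C)C(=O)[C@@H]1[C@H]3C(=O)N(c4ccc(Cl)cc4)C(=O)[C@H]3ON12`: in this assay compound 3 gives 74%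

The three values sit within the scatter of one another. Compound 3 is separated from compound 2 by a number 0.5 percentage points higher from compound 2 to compound 3 (within the scatter) and from compound 1 by a number 1.3 percentage points lower from compound 1 to compound 3 (within the scatter), so nothing on these numbers sets compound 3 apart from either.

Compound 4 is `CC(C)[C@@H]1CC[C@@H](C)C[C@@]12N(C)C(=O)[C@@H]1[C@H]3C(=O)N(c4ccc5ccccc5c4)C(=O)[C@H]3ON12`. Its difference from compound 3 is naphthalen-2-yl in place of 4-chlorophenyl on an amide-type nitrogen in a ring.

For the measured compounds named here, three measured steps bear on this, all of them exchanges on the same amide-type nitrogen in the ring or on the aromatic ring attached to it: a number 1.8 percentage points lower from compound 1 to compound 2 (within the scatter), a number 1.3 percentage points lower from compound 1 to compound 3 (within the scatter) and a number 0.5 percentage points higher from compound 2 to compound 3 (within the scatter). None of them left the scatter, and the swap of methyl for phenyl or 4-chlorophenyl, or of hydrogen for chloro on that phenyl, moved the read-out in this assay by amounts too small to count. On that basis a naphthalen-2-yl in the same place is expected to behave alike, giving an expected step of no change at the digits printed from compound 3 to compound 4 (within the scatter) that stays within the scatter. Compound 4 is accordingly estimated at 74% in this assay, with an expected range from 64% to 84%.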

Compound 4, a percentage reported as activity, at one concentration (the size of the read-out at that concentration, not a potency): 60.1%
The estimate for compound 4 lay 13.9 percentage points above the measured number; the whole stated range lies above it.
By their numbers in this assay, from the lowest: compound 4; then compounds 2, 3 and 1 (each within the scatter of the next).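

In this assay the amide-type nitrogen in a ring is no longer a silent position: naphthalen-2-yl there gives a number 13.9 percentage points lower from compound 3 to compound 4 (beyond the scatter) and a number 13.4 percentage points lower from compound 2 to compound 4 (beyond the scatter) and a number 15.2 percentage points lower from compound 1 to compound 4 (beyond the scatter) when set against 4-chlorophenyl, phenyl and methyl in turn. The earlier exchanges among those three groups stayed within the scatter, so this position accepts a single six-membered aromatic ring of carbon as readily as methyl, while the change to two such rings lowers the read-out, though compound 4 still gives 60.1% and the effect is reduced rather than lost, a finding that rests on this one compound. Nothing available on these compounds accounts for the lower number.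

Open, from the compounds shown here alone, is whether the drop belongs to the second aromatic ring as such or to this particular attachment, which naphthalen-1-yl or biphenyl-4-yl on the same nitrogen would help to separate. Also open, going by these compounds, is how a benzyl group, or a phenyl ring carrying an amine or a carboxylic acid, would read at this position, and whether the drop seen at the one concentration tested would hold at others.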